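A trifluoromethyl group on compound 1 and cell tolerance

A few compounds are considered here, and "the series" means these few. Any claim that something is new, unique, unknown or untested is made for them only; others in the source may bear on it.

Measured in an ADME assay on Vero cells (Chlorocebus sabaeus) for cytotoxicity, read by MTT assay, with a stated time of 72 h; a higher number here means that more compound is tolerated, a lower number that less compound is tolerated:
- compound 1 `O=C(N/N=C/c1ccccc1)c1ccc([N+](=O)[O-])o1` gives "not determined" (no result reported)
- compound 2 `O=C(N/N=C/c1ccc(O)cc1)c1ccc([N+](=O)[O-])o1` gives "not determined" (no result reported)
- compound 3 `Cc1ccc(/C=N/NC(=O)c2ccc([N+](=O)[O-])o2)cc1` gives > 228000 nM as a limit of the assay, not a number

Compound 1 has no single number in this assay and stands without a result ("not determined" (no result reported)) to start from. Compound 3 supplies the one reference (the limit of > 228000 nM in this assay, at which 1 of the 3 values shown sits) and that is a limit, not a number.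

The compound that follows is compound 4 `O=C(N/N=C/c1ccccc1C(F)(F)F)c1ccc([N+](=O)[O-])o1` with its structure changed from the parent (trifluoromethyl in place of hydrogen on an aromatic carbon) by trifluoromethyl in place of hydrogen on an aromatic carbon, ortho to a large group. Among the compounds with values here, no measured step shows what this kind of change does. The expectation in this assay is therefore a step no larger than the usual scatter, in neither direction, with high concentrations still tolerated and a fair chance that only a limit is reported. For compound 4 the estimated half-maximal cytotoxic concentration is 120000 nM with an expected range from 25000 nM to 300000 nM in this measurement.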

Compound 4, half-maximal cytotoxic concentration: > 191000 nM
Compound 4 gave a limit, no number; the forecaster's own chance of this, stated with the estimate: 45%; middle value at least 1.5-fold (0.20 log units) away from the limit.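

Compound 4 gives > 191000 nM, a limit and not a number. Within the data shown here, with no single number for compound 1 either, no step between these two compounds can be read. The compounds shown leave open what trifluoromethyl in place of hydrogen on an aromatic carbon does in this assay.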